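Swapping the Epoxide Side Chain for Acetyl

The source may hold more compounds than are shown below. What is called first, only, known or untested is meant among the compounds shown, and "the series" means these compounds.

Compounds measured so far:
- compound 1, `CCc1cc(C(C)=O)c(O)cc1OCCCCC#N`: 92%
- compound 2, `CCCCc1cc(C(C)=O)c(O)cc1OCCCCC#N`: 41%
- compound 3, `CC(=O)c1cc(CC2CO2)c(OCCCCC#N)cc1O`: 62%

In an assay on isolated protein for inhibition of leukotriene B4 receptor 1 (Homo sapiens), tested at 10 uM (on this read-out lower numbers stand for less inhibition and higher numbers for more inhibition at the one concentration tested (going by the name of the read-out)), compound 3 sits second highest of the three numbers; its nearest neighbour is compound 2, and the step of a number 21 percentage points higher from compound 2 to compound 3 (beyond the scatter) separates them, while the step of a number 30 percentage points lower from compound 1 to compound 3 (beyond the scatter) puts compound 1 clearly above it.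

Compound 4, `CC(=O)c1cc(C(C)=O)c(OCCCCC#N)cc1O`, differs from compound 3 in one place: acetyl in place of (oxiran-2-yl)methyl on an aromatic carbon.

For the measured compounds named here, no measured step exchanges a chain-bearing group for acetyl at this aromatic carbon. The two steps that touch the same position, a number 30 percentage points lower from compound 1 to compound 3 (beyond the scatter) and a number 21 percentage points higher from compound 2 to compound 3 (beyond the scatter), show that changing the group on that carbon moves the read-out by modest amounts in either direction. Going by the values given here, that is the only guidance available, and it gives no direction for acetyl.

Compound 4 is therefore expected to land near compound 3, with the estimated step of a number 7 percentage points lower from compound 3 to compound 4 (within the scatter) likely within the scatter, giving an estimate of 55% with a range from 25% to 85%.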

Compound 4, a percentage reported as inhibition, at one concentration (the size of the read-out at that concentration, not a potency): 8%
Compound 4: the middle estimate sits 47 percentage points above what was measured, and the stated range ends above it.
By their numbers in this assay, from the lowest: compound 4; then compound 2; then compound 3; then compound 1.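

On the aromatic carbon ortho to a 4-cyanobutoxy group, acetyl gives the lowest number of the series in this assay, with a number 54 percentage points lower from compound 3 to compound 4 (beyond the scatter), a number 33 percentage points lower from compound 2 to compound 4 (beyond the scatter) and a number 84 percentage points lower from compound 1 to compound 4 (beyond the scatter). Acetyl and the (oxiran-2-yl)methyl it replaces have the same counts of hydrogen-bond donors and acceptors, so those counts do not separate them, whereas acetyl has no ring and has a double bond outside aromatic rings. The earlier compounds shown here showed only moderate to high inhibition with ethyl, butyl or (oxiran-2-yl)methyl here, whereas this change shows that the group on this carbon can take inhibition down to a low number.

No measurement shown bears on why acetyl behaves this way. Also open, on these data alone, is how a hydroxymethyl group, an aminomethyl group or a carboxylic acid would read on this carbon.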